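The source may hold more compounds than are shown below. What is called first, only, known or untested is meant among the compounds shown, and "the series" means these compounds.

Measured in a functional assay on liver (Rattus norvegicus, strain Sprague-Dawley) for inhibition, with a stated time of 1 h; a lower number here means a stronger inhibitor, a higher number a weaker inhibitor:
- compound 1 `COc1cc(C2Oc3cc([C@H]4Oc5cc(O)cc(O)c5C(=O)[C@@H]4O)ccc3OC2COC(=O)c2ccccc2)ccc1O`: 12700 nM
- compound 2 `CCOC(=O)CC(=O)OCC1Oc2ccc([C@H]3Oc4cc(O)cc(O)c4C(=O)[C@@H]3O)cc2OC1c1ccc(O)c(OC)c1`: 33400 nM
- compound 3 `COc1cc(C2Oc3cc([C@H]4Oc5cc(O)cc(O)c5C(=O)[C@@H]4O)ccc3OC2COC(=O)c2cc(N)cc([N+](=O)[O-])c2)ccc1O`: 200 nM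

Compound 3 has the lowest number of the three, and its steps to both others lie beyond the scatter. Compound 4 `COc1cc(C2Oc3cc([C@H]4Oc5cc(O)cc(O)c5C(=O)[C@@H]4O)ccc3OC2COC(=O)/C=C/c2ccc(C)cc2)ccc1O` differs from it by 2-(4-methylphenyl)ethenyl in place of 3-amino-5-nitrophenyl on a carbonyl carbon, with 2-(4-methylphenyl)ethenyl in place of 3-amino-5-nitrophenyl on a carbonyl carbon. Two large steps bear on this: a 64-fold lower number from compound 1 to compound 3 (1.80 log units; beyond the scatter) and a 170-fold lower number from compound 2 to compound 3 (2.22 log units; beyond the scatter), both bringing in 3-amino-5-nitrophenyl. The step of a 2.6-fold higher number from compound 1 to compound 2 (0.42 log units; beyond the scatter) is only modest. Neither compound 1 nor compound 2 has an ethenyl group, so the transfer is uncertain, but a large step to a higher number is expected in this assay. The expected step is a 25-fold higher number from compound 3 to compound 4 (1.40 log units; beyond the scatter). The estimate for compound 4 is 5000 nM, within an expected range of 700 nM to 25000 nM.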

Compound 4, half-maximal inhibitory concentration: 14700 nM
The estimate for compound 4 lay 2.9-fold (0.47 log units) below the measured number; the range from low to high includes it.
By their numbers in this assay, from the lowest: compound 3; then compounds 1 and 4 (each within the scatter of the next); then compound 2.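

At this carbonyl carbon in this assay, 2-(4-methylphenyl)ethenyl does not keep the low number given by 3-amino-5-nitrophenyl (a 74-fold higher number from compound 3 to compound 4 (1.87 log units; beyond the scatter)). It is indistinguishable from phenyl (a 1.2-fold higher number from compound 1 to compound 4 (0.06 log units; within the scatter)) and only modestly lower than (ethoxycarbonyl)methyl (a 2.3-fold lower number from compound 2 to compound 4 (0.36 log units; beyond the scatter)), so among these four compounds 3-amino-5-nitrophenyl alone stands apart. No measurement available here explains these steps.

Open, from the compounds shown here alone, is whether both substituents are needed for the low number. A 3-aminophenyl or a 3-nitrophenyl group at this carbonyl carbon would separate the two.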